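The source may hold more compounds than are shown below. What is called first, only, known or untested is meant among the compounds shown, and "the series" means these compounds.

In a toxicity assay on THP-1 cells (Homo sapiens) for inhibition (on this read-out lower numbers stand for higher toxicity in this test and higher numbers for lower toxicity in this test), compound 1 `COc1ccc(-c2cnc(NC(=O)c3ccc(O)cc3)n2C)cc1` gives only a limit, > 100000 nM. Compound 2 `COc1ccc(-c2cnc(NC(=O)c3ccc(F)cc3)n2C)cc1` likewise gives only a limit in this assay, >= 50000 nM. Going by the values given here, the single measured step, a step that the two limits leave unreadable from compound 1 to compound 2, has no readable size, since both values sit at limits: the limit of > 100000 nM in this assay, at which 1 of the 2 values shown sits, and (the limit of >= 50000 nM in this assay, at which 1 of the 2 values shown sits). Compound 3 `COc1ccc(-c2cnc(NC(=O)c3ccccc3Cl)n2C)cc1` differs from compound 2 by 2-chlorophenyl in place of 4-fluorophenyl on a carbonyl carbon. Among the compounds with values here, no measured step bears on this change, so no shift beyond the scatter is expected in this assay. The step from compound 2 to compound 3 is estimated at a number no higher from compound 2 to compound 3 (the limit leaves the size open). Compound 3 is expected to give 50000 nM in this assay, between 20000 nM and 150000 nM.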

Compound 3, half-maximal cytotoxic concentration: > 50000 nM
Compound 3 gave a limit, no number; the forecaster's own chance of this, stated with the estimate: 65%; the middle value lies on the limit itself.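

Going by these compounds alone, no step among compound 1, compound 2 and compound 3 can be read: all three values are limits. The compounds shown leave open whether 4-hydroxyphenyl, 4-fluorophenyl or 2-chlorophenyl on the carbonyl carbon makes any difference in this assay.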